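The source may hold more compounds than are shown below. What is called first, only, known or untested is meant among the compounds shown, and "the series" means these compounds.

The account follows two measured compounds and one still untested, all read in a functional assay on DU-145 cells (Homo sapiens) for inhibition, read by trypan blue exclusion, with a stated time of 96 h; on this read-out lower numbers stand for stronger inhibition of growth and higher numbers for weaker inhibition of growth. Compound 1, `Cc1ccc(CS(=O)(=O)/C(=C/c2cccc(Cl)c2Cl)C(=O)c2ccc(Cl)cc2)cc1`, gives 1000 nM in this assay. Compound 2, `O=C(/C(=C\c1c[nH]c2ccccc12)S(=O)(=O)c1ccc(Br)cc1)c1ccc(Br)cc1`, gives 25000 nM in this assay. Within the data shown here, compound 1 therefore stands at the lower of the two numbers, and compound 2 sits at a higher number by a gap that lies beyond the scatter of repeated measurements; since no single-point step connects the two, their values only show where each stands. The compound yet to be measured is compound 3, `Cc1ccc(CS(=O)(=O)/C(=C/c2ccccc2Br)C(=O)c2ccc(Cl)cc2)cc1`. It differs from compound 1 in one place: 2-bromophenyl in place of 2,3-dichlorophenyl on a double-bonded chain carbon bound to a double-bonded chain carbon. Among the measured compounds shown here, no step between measured compounds bears on this kind of change, so the expectation rests only on compound 1 and on the change itself. The step of a 1.5-fold higher number from compound 1 to compound 3 (0.18 log units; within the scatter) is expected to be small, toward a slightly higher number, and not clearly beyond the scatter. On that basis compound 3 is estimated at 1500 nM in this assay, with a range from 500 nM to 5000 nM.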

Compound 3, concentration for 50% growth inhibition: 25000 nM
Compound 3: middle estimate off by 17-fold (1.22 log units), on the low side, and the stated range ends below it.
By their numbers in this assay, from the lowest: compound 1; then compounds 2 and 3 (each within the scatter of the next).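

In this assay the group at the place on a double-bonded chain carbon bound to a double-bonded chain carbon proves far from interchangeable: putting 2-bromophenyl in place of 2,3-dichlorophenyl gives a 25-fold higher number from compound 1 to compound 3 (1.40 log units; beyond the scatter) with the rest of the structure unchanged. The earlier compounds shown here could not show this, since compound 1 and compound 2 are joined by no single-point step, whereas this pair ties a large loss of growth inhibition to one place, in a change that swaps two chlorine atoms for one bromine atom on a ring of the same size and leaves hydrogen-bond donors and acceptors unchanged in the count. Nothing measured here explains why the step is so large.

The compounds shown leave open whether the loss follows from the departure of 2,3-dichlorophenyl or from the arrival of 2-bromophenyl, since the single pair changes both together. They also leave open how a phenyl ring carrying an amine, a methoxy group or a carboxylic acid would read at this place on the core of compound 1.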